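Aromatic substitution on the phenoxy side of the shared core

The source may report more compounds than this note shows. Statements on the series, on what has been measured and on what is new or still open speak of the compounds shown alone.

Compound 1 `Cc1ncc([N+](=O)[O-])n1CCOc1ccccc1` is the unsubstituted reference of this set. In a functional assay on A549 cells (Homo sapiens) for cytotoxicity, read by MTT assay, with a stated time of 24 h (a higher number here means a weaker inhibitor, a lower number a stronger inhibitor), compound 1 gives 107 ug/mL, the lowest number among the three measured compounds. Compound 2 `Cc1ncc([N+](=O)[O-])n1CCOc1ccccc1Cl` gives 574 ug/mL in this assay, and compound 3 `Cc1cc(OCCn2c([N+](=O)[O-])cnc2C)ccc1F` gives 226 ug/mL. Compound 2 differs from compound 1 in one place, and the step of a 5.4-fold higher number from compound 1 to compound 2 (0.73 log units; beyond the scatter) shows that a single substituent on the six-membered aromatic ring of carbon only moved the number upward by a clear margin. Among the measured compounds shown here, compound 3 carries two changes against compound 1, so no single step is drawn from it; its number simply stands above that of compound 1.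

Compound 4 `Cc1ncc([N+](=O)[O-])n1CCOc1ccc([N+](=O)[O-])cc1` is not yet measured. It differs from compound 1 by nitro in place of hydrogen on an aromatic carbon. For the measured compounds named here, the only measured step that bears on this change is the one from compound 1 to compound 2, which raised the number; on that basis a modest rise beyond the scatter is expected for compound 4, a 1.8-fold higher number from compound 1 to compound 4 (0.25 log units; within the scatter). Compound 4 is therefore estimated at 190 ug/mL in this assay, with a range from 75 ug/mL to 480 ug/mL.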

Compound 4, half-maximal inhibitory concentration: 110 ug/mL
Compound 4: the middle estimate sits 1.7-fold (0.24 log units) above what was measured; the range from low to high includes it.
By their numbers in this assay, from the lowest: compounds 1 and 4 (each within the scatter of the next); then compound 3; then compound 2.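

Compounds 1 and 4 stand within the scatter of each other in this assay, as shown by a 1.0-fold higher number from compound 1 to compound 4 (0.01 log units; within the scatter), so nitro at this place, para to a large group, gives no measurable separation from hydrogen. The earlier result therefore does not extend to every substituent on this ring: a 5.4-fold higher number from compound 1 to compound 2 (0.73 log units; beyond the scatter) lies beyond the scatter, whereas the nitro step does not, although the two substituted compounds differ in both the group and its place, so the contrast cannot be assigned to either alone. Nothing measured here accounts for this contrast.

Still open, from the compounds shown here alone, is whether chloro at the place held by nitro would give a step like that of nitro or like its own. An amine or a carboxylic acid at this same place would show whether other groups also stay within the scatter of compound 1.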